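The source may hold more compounds than are shown below. What is called first, only, known or untested is meant among the compounds shown, and "the series" means these compounds.

Measured compounds in a physicochemical assay for solubility, measured as kinetic solubility; on this read-out lower numbers stand for lower solubility and higher numbers for higher solubility:
Compound 1 `O=c1nc(-c2ccccc2)c2cc(-c3cc[nH]n3)ccc2[nH]1`: in this assay compound 1 gives 8000 nM.
Compound 2 `O=c1nc(-c2ccccc2)c2cc(N3CCNCC3)ccc2[nH]1`: in this assay compound 2 reaches only a limit, > 1000000 nM.
Compound 3 `Cc1ccccc1-c1nc(=O)[nH]c2ccc(-c3cc[nH]n3)cc12`: in this assay compound 3 gives 13000 nM.

Compound 3 and compound 1 lie within the scatter of each other, as the step of a 1.6-fold higher number from compound 1 to compound 3 (0.21 log units; within the scatter) shows. Compound 2 stands at a limit of the assay (the limit of > 1000000 nM in this assay, at which 1 of the 3 values shown sits), so no number is available for it.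

Compound 4 `O=c1nc(C2CCCCC2)c2cc(-c3cc[nH]n3)ccc2[nH]1` differs from compound 3 by cyclohexyl in place of 2-methylphenyl on an aromatic carbon. Neither measured step matches this change. The step of an at least 120-fold higher number from compound 1 to compound 2 (2.09 log units; beyond the scatter) concerns a different part of the core and a different kind of group; the step of a 1.6-fold higher number from compound 1 to compound 3 (0.21 log units; within the scatter) touches the 2-methylphenyl but only adds a methyl to it. Among the compounds with values here, none of the measured compounds shows what exchanging the aromatic ring for a saturated ring at this place does, so no step beyond the scatter is expected. For compound 4 the number in this assay is estimated at 13000 nM, between 4000 nM and 40000 nM. The expected step of no change at the digits printed from compound 3 to compound 4 (within the scatter) lies within the scatter.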

Compound 4, solubility: 5000 nM
Compound 4: the middle estimate sits 2.6-fold (0.41 log units) above what was measured, and the stated range covers the measured number.
By their numbers in this assay, from the lowest: compounds 4, 1 and 3 (each within the scatter of the next, the first and the last beyond it). At a limit, above all of these: compound 2.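

Cyclohexyl in place of 2-methylphenyl on this aromatic carbon gives a 2.6-fold lower number from compound 3 to compound 4 (0.41 log units; beyond the scatter) in this assay, the first step at this place that lies beyond the scatter. Cyclohexyl in place of phenyl at the same place gives a 1.6-fold lower number from compound 1 to compound 4 (0.20 log units; within the scatter), so the exchange of an aromatic ring for a saturated one shows a readable step only against the methylated ring of compound 3, not against the plain phenyl of compound 1. Nothing measured on these compounds accounts for the step.

All groups shown at this place are six-membered rings of carbon only, so the effect of a carboxylic acid or an aminomethyl group here remains open. Also open, going by these compounds, is whether an at least 120-fold higher number from compound 1 to compound 2 (2.09 log units; beyond the scatter) would carry over to the cyclohexyl series.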